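Iodo for bromo: the next halogen step

The compounds below may be only part of what the source reports. "The series", "measured", "known", "first", "only" and "open" are said of these compounds alone.

Compound 1, `CC(C)(C)OC(=O)NN(Cc1ccccc1)C(=O)CCl` — > 100000 nM in an assay on isolated protein for inhibition of RAC-alpha serine/threonine-protein kinase (Homo sapiens), read by Z'-LYTE, with a stated time of 1 h, in the presence of a further agent that is not named here; a higher number here means a weaker inhibitor, a lower number a stronger inhibitor
Compound 2, `CC(C)(C)OC(=O)NN(Cc1ccccc1)C(=O)CBr` — 24700 nM in this assay

Of the compounds shown here, two have been measured. Compound 1 carries a chloro group and reaches the limit of the assay, > 100000 nM, which is a limit and not a number. Compound 2 carries a bromo group in its place and gives 24700 nM in this assay; it is the only finite number shown. Among the compounds with values here, the other entry, that of compound 1, is a limit, so compound 2 stands alone as the one compound with a measured value. Within the data shown here, the single measured step, an at least 4.0-fold lower number from compound 1 to compound 2 (0.60 log units; beyond the scatter), runs from that limit to the finite value, and because the limit of > 100000 nM in this assay, at which 1 of the 2 values shown sits, only the floor of its size is known.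

Compound 3, `CC(C)(C)OC(=O)NN(Cc1ccccc1)C(=O)CI`, differs from compound 2 by iodo in place of bromo on a saturated chain carbon bound to a carbonyl carbon. The bromo-for-chloro step bears on it directly: the same kind of halogen exchange in the same place gave a lower number. A further step in the same sense, downward and beyond the scatter, is therefore expected in this assay. Compound 3 is estimated at 8000 nM, within a range of 2000 nM to 40000 nM. That estimate implies the expected step of a 3.1-fold lower number from compound 2 to compound 3 (0.49 log units; beyond the scatter).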

Compound 3, half-maximal inhibitory concentration: 16100 nM
Compound 3: the middle estimate sits 2.0-fold (0.30 log units) below what was measured, and the stated range covers the measured number.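

Iodo in place of bromo on a saturated chain carbon bound to a carbonyl carbon gave a 1.5-fold lower number from compound 2 to compound 3 (0.19 log units; within the scatter), so compound 2 and compound 3 cannot be told apart in this assay, and the clear gain seen on going from chloro to bromo does not carry on to the next halogen. Iodo in place of chloro at the same place gave an at least 6.2-fold lower number from compound 1 to compound 3 (0.79 log units; beyond the scatter), so at this position bromo and iodo each part from chloro by a step beyond the scatter, while they do not part from each other. The size of that step from chloro is known only as a floor, because of the value at which it starts: the limit of > 100000 nM in this assay, at which 1 of the 3 values shown sits.

The compounds shown leave open whether a group other than a halogen at this place, such as an amine, a hydroxyl or a thiol, would fall in the same range in this assay, and whether a longer chain carrying the bromo group would keep the number of compound 2. They also leave open how much of the numbers of compound 2 and compound 3 rests on the shared core, which stays the same throughout.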